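Replacing a Sulfanylphenyl by a Methylphenyl on a Fused Core

The source may report more compounds than this note shows. Statements on the series, on what has been measured and on what is new or still open speak of the compounds shown alone.

Compound 1 `Cc1nc2c3ccccc3ccc2c2nc3c(ccc4ccccc43)c(-c3nccnc3N)c12`: 2260 nM
Compound 2 `COc1ccc(-c2c3ccc4ccccc4c3nc3c2c(C)nc2c4ccccc4ccc32)cc1`: 66400 nM
Compound 3 `Cc1nc2c3ccccc3ccc2c2nc3c(ccc4ccccc43)c(-c3ccccc3S)c12`: 4070 nM

All three numbers come from a functional assay on AGS cells (Homo sapiens) for cytotoxicity, read by MTT assay, with a stated time of 48 h; a higher number here means a weaker inhibitor, a lower number a stronger inhibitor. Compound 3 holds the second highest of the three numbers. Its nearest neighbour is compound 1, with a 1.8-fold higher number from compound 1 to compound 3 (0.26 log units; within the scatter); its furthest is compound 2, with a 16-fold lower number from compound 2 to compound 3 (1.21 log units; beyond the scatter). The shared core is unchanged across the set; only the aryl group on the core varies.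

Compound 4 `Cc1ccc(-c2c3ccc4ccccc4c3nc3c2c(C)nc2c4ccccc4ccc32)cc1` has not yet been measured. Its difference from compound 3 is 4-methylphenyl in place of 2-sulfanylphenyl on an aromatic carbon. Within the data shown here, two measured steps bear on this change. The step of a 16-fold lower number from compound 2 to compound 3 (1.21 log units; beyond the scatter) ran in the opposite sense, from a para-substituted phenyl with no donor or acceptor to the 2-sulfanylphenyl, and was large. The step of a 29-fold higher number from compound 1 to compound 2 (1.47 log units; beyond the scatter) likewise showed that the 4-methoxyphenyl gave a far higher number than the 3-aminopyrazin-2-yl. Compound 4 carries a 4-methylphenyl, again a para-substituted phenyl with no donor or acceptor, so a large rise in the number is expected, though not necessarily the full size seen with compound 2. Compound 4 is therefore estimated at 30000 nM, within a range of 6000 nM to 120000 nM, which is expected to amount to a 7.4-fold higher number from compound 3 to compound 4 (0.87 log units; beyond the scatter).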

Compound 4, half-maximal inhibitory concentration: > 80000 nM
Compound 4 ended at the assay's limit; the forecaster's own chance of this, stated with the estimate: 10%; middle value at least 2.6-fold (0.42 log units) away from the limit.
By their numbers in this assay, from the lowest: compounds 1 and 3 (each within the scatter of the next); then compound 2. At a limit, above all of these: compound 4.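

In this assay, compound 4 stands at a limit rather than at a number: the limit of > 80000 nM in this assay, at which 1 of the 4 values shown sits. Even so, the limit is enough to show that the position is sensitive to this change, with an at least 19-fold higher number from compound 3 to compound 4 (1.29 log units; beyond the scatter) and an at least 35-fold higher number from compound 1 to compound 4 (1.54 log units; beyond the scatter); the 2-sulfanylphenyl, with 1 hydrogen-bond donor and 1 hydrogen-bond acceptor, gives way here to a 4-methylphenyl with neither, while the heavy-atom count stays the same. The remaining comparison adds that methyl in place of methoxy on the phenyl ring cannot be told apart from no change, with an at least 1.2-fold higher number from compound 2 to compound 4 (0.08 log units; that floor lies within the scatter), so the high number seen earlier with the 4-methoxyphenyl of compound 2 now has a companion in the 4-methylphenyl of compound 4.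

The change from compound 3 to compound 4 alters both the substituent and its place on the phenyl ring, so the compounds shown do not separate the effect of the sulfanyl group from that of where it sits. They also leave open whether an amine or a hydroxyl on that phenyl ring would give a number nearer to those of compound 1 and compound 3.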